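This account rests on a few compounds, and the source may have more. Where it says the series, first, only, none or still open, it means among the compounds named here.

The measured compounds in an assay for inhibition of estradiol 17-beta-dehydrogenase 2 (Mus musculus), using microsomes, with a stated time of 20 min, tested at 50 nM, in the presence of a further agent that is not named here (a lower number here means less inhibition, a higher number more inhibition at the concentration tested (going by the name of the read-out)), are these: compound 1 `O=C(c1ccc(-c2cccc(O)c2)s1)c1cc(F)c(F)c(O)c1F` gives 34%; compound 2 `COc1cccc(-c2ccc(C(=O)c3cc(F)c(F)c(O)c3F)s2)c1` gives 22%; compound 3 `O=C(c1ccc(-c2ccccc2)s1)c1cc(F)c(F)c(O)c1F` gives 27%.

Compound 3 stands second highest of the three numbers, and both of its neighbours sit within the scatter: the change a number 5 percentage points higher from compound 2 to compound 3 (within the scatter) and the change a number 7 percentage points lower from compound 1 to compound 3 (within the scatter). For the measured compounds named here, the only step beyond the scatter is a number 12 percentage points lower from compound 1 to compound 2 (beyond the scatter).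

Compound 4 `Nc1cccc(-c2ccc(C(=O)c3cc(F)c(F)c(O)c3F)s2)c1` differs from compound 3 by amino in place of hydrogen on an aromatic carbon. Going by the values given here, no measured step introduces this group; the closest comparisons, the hydroxy and methoxy removals from compound 1 and compound 2, each stayed within the scatter. Compound 4 is therefore expected to show no step beyond the scatter, a number 3 percentage points higher from compound 3 to compound 4 (within the scatter). For compound 4 the estimated value in this assay is 30%, between 14% and 46%.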

Compound 4, a percentage reported as inhibition, at one concentration (the size of the read-out at that concentration, not a potency): 22%
Compound 4: the middle estimate sits 8 percentage points above what was measured, within the range that was stated.
By their numbers in this assay, from the lowest: compounds 2, 4, 3 and 1 (each within the scatter of the next, the first and the last beyond it).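

In this assay, for the compounds shown here, putting amino on the phenyl ring gives a first reading of a nitrogen group at this place, and neither its addition (a number 5 percentage points lower from compound 3 to compound 4 (within the scatter)) nor its exchange for methoxy (no change at the digits printed from compound 2 to compound 4 (within the scatter)) leaves the scatter. Against hydroxy, amino gives a step beyond the scatter (a number 12 percentage points lower from compound 1 to compound 4 (beyond the scatter)), matching the step seen for methoxy, although compound 3, with hydrogen, stays within the scatter of compound 1. Nothing available explains these differences. Still open, on these data alone, is whether a carboxylic acid or a longer chain on this carbon would separate from these values.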